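Morpholin-4-yl in place of oxan-4-yl on compound 3

A few compounds are considered here, and "the series" means these few. Any claim that something is new, unique, unknown or untested is made for them only; others in the source may bear on it.

Measured so far in an ADME assay on microsomes from liver (Mus musculus) for metabolic stability, with a stated time of 10 min (a higher number here means that more of the compound is left, a lower number that less of the compound is left), for three compounds:
compound 1 `CC(=O)N1CC[C@H](C(=O)N2CC[C@](c3ccc(C(OCc4c(F)cccc4F)(C(F)(F)F)C(F)(F)F)cc3)(S(=O)(=O)c3ccc(F)cc3)C2)C1` gives 57%
compound 2 `CC(=O)N1CCC(C)(C(=O)N2CC[C@](c3ccc(C(OCc4c(F)cccc4F)(C(F)(F)F)C(F)(F)F)cc3)(S(=O)(=O)c3ccc(F)cc3)C2)CC1` gives 4%
compound 3 `O=C(C1CCOCC1)N1CC[C@](c2ccc(C(OCc3c(F)cccc3F)(C(F)(F)F)C(F)(F)F)cc2)(S(=O)(=O)c2ccc(F)cc2)C1` gives 29%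

Compound 3 stands second of the three, below compound 1 and above compound 2, and both gaps lie beyond the scatter. The difference morpholin-4-yl in place of oxan-4-yl on a carbonyl carbon leads to compound 4 `O=C(N1CCOCC1)N1CC[C@](c2ccc(C(OCc3c(F)cccc3F)(C(F)(F)F)C(F)(F)F)cc2)(S(=O)(=O)c2ccc(F)cc2)C1`, with morpholin-4-yl in place of oxan-4-yl on a carbonyl carbon.

All three measured steps change the group at this same carbonyl carbon. The step of a number 53 percentage points lower from compound 1 to compound 2 (beyond the scatter) is large, while a number 28 percentage points lower from compound 1 to compound 3 (beyond the scatter) and a number 25 percentage points higher from compound 2 to compound 3 (beyond the scatter) are modest. For the measured compounds named here, this place can therefore shift the read-out, but no measured pair makes the change from oxan-4-yl to morpholin-4-yl, so the direction rests on little. No step beyond the scatter is expected, though a modest one in either direction remains possible, which keeps the range wide.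

The expected change is a number 4 percentage points higher from compound 3 to compound 4 (within the scatter) in this assay on this estimate. The estimated value for compound 4 is 33% (expected range 14% to 55%) in this assay at this stage.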

Compound 4, percent of the compound remaining: 18%
The estimate for compound 4 lay 15 percentage points above the measured number; the measured number falls inside the stated range.
By their numbers in this assay, from the lowest: compound 2; then compound 4; then compound 3; then compound 1.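

In this assay the exchange of oxan-4-yl for morpholin-4-yl on the carbonyl carbon gives a number 11 percentage points lower from compound 3 to compound 4 (beyond the scatter) and shows that a swap between two six-membered rings of equal heavy-atom count can move the read-out at this position. Morpholin-4-yl also falls within the span set by the two acetylated groups, with a number 39 percentage points lower from compound 1 to compound 4 (beyond the scatter) and a number 14 percentage points higher from compound 2 to compound 4 (beyond the scatter) as the steps that place it there. Nothing available accounts for the lower number with morpholin-4-yl.

As far as these compounds go, this rests on a single pair, on one core, so it remains open whether the same step would appear in the core of compound 1 or compound 2. Also open, from the compounds shown here alone, is how a piperidin-1-yl or a dimethylamino group on the same carbonyl carbon would compare with morpholin-4-yl.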